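The source may report more compounds than this note shows. Statements on the series, on what has been measured and on what is new or still open speak of the compounds shown alone.

Measured compounds:
compound 1, `CCc1cnc(N2CCC(c3nc(COc4ccc(/C=C5\CC(=O)NC5=O)cc4)cs3)CC2)nc1`, 182 nM
compound 2, `CCc1cnc(N2CCC(c3nc(COc4ccc(/C=C5\CC(=O)NC5=O)cc4C)cs3)CC2)nc1`, 18 nM

Compound 2 stands at the lowest of the two numbers in a functional assay on cells for agonist activity at Glucose-dependent insulinotropic receptor (Homo sapiens), read by a luciferase reporter, with a stated time of 6 h; a lower number here means that less compound is needed, a higher number that more compound is needed for the effect; its nearest neighbour is compound 1, and the step of a 10-fold lower number from compound 1 to compound 2 (1.00 log units; beyond the scatter) lies beyond the scatter. Compound 3, `Cc1cc(/C=C2\CC(=O)NC2=O)ccc1OCc1csc(C2CCN(C(=O)OC(C)(C)C)CC2)n1`, differs from compound 2 in one place: tert-butoxycarbonyl in place of 5-ethylpyrimidin-2-yl on an amine nitrogen in a ring. Going by the values given here, the only measured step, a 10-fold lower number from compound 1 to compound 2 (1.00 log units; beyond the scatter), concerns a methyl on an aromatic carbon and does not touch the amine nitrogen in the ring; no measured pair informs the exchange of the 5-ethylpyrimidin-2-yl for tert-butoxycarbonyl. The expectation for compound 3 rests on the structural change alone and carries wide uncertainty. Compound 3 is expected to give a higher number in this assay than compound 2, estimated as an 83-fold higher number from compound 2 to compound 3 (1.92 log units; beyond the scatter). The estimate for compound 3 in this assay is 1500 nM, with a range from 200 nM to 10000 nM.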

Compound 3, half-maximal effective concentration: 19 nM
Compound 3: the middle estimate sits 79-fold (1.90 log units) above what was measured, and the stated range ends above it.
By their numbers in this assay, from the lowest: compounds 2 and 3 (each within the scatter of the next); then compound 1.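

In this assay, tert-butoxycarbonyl in place of 5-ethylpyrimidin-2-yl on the amine nitrogen in a ring gives a 1.1-fold higher number from compound 2 to compound 3 (0.02 log units; within the scatter). The earlier compounds shown here varied only the methyl on an aromatic carbon; this pair shows that, with that methyl present, the six-membered aromatic ring with 2 hetero atoms is not required at the amine nitrogen, as a group with no ring gives a number within the scatter of compound 2. No available evidence accounts for this tolerance.

The compounds shown leave open whether the exchange holds on the core of compound 1, which lacks the methyl. Also open, from the compounds shown here alone, is how far this tolerance extends at the amine nitrogen, for example to an acetyl, a benzyl or a plain hydrogen.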